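Ring the amine: from cyclopropylamino to azetidinyl

The source may report more compounds than this note shows. Statements on the series, on what has been measured and on what is new or still open speak of the compounds shown alone.

Measured compounds:
Compound 1, `CC(C)(C)CNCc1ccc2c(c1)CCC[C@H]2NC(=O)C[C@@H]1CCCCN1S(=O)(=O)c1cccc(C(F)(F)F)c1`, 230 nM
Compound 2, `O=C(C[C@@H]1CCCCN1S(=O)(=O)c1cccc(C(F)(F)F)c1)N[C@@H]1CCCc2cc(CNC3CC3)ccc21`, 47 nM

In a functional assay for inhibition of B1 bradykinin receptor (Homo sapiens), read by calcium flux (a lower number here means a stronger inhibitor, a higher number a weaker inhibitor), compound 2 gives 47 nM, the lowest of the two numbers recorded; compound 1 gives 230 nM, and the step of a 4.9-fold lower number from compound 1 to compound 2 (0.69 log units; beyond the scatter) is the only one measured so far, lying beyond the scatter. Compound 3, `O=C(C[C@@H]1CCCCN1S(=O)(=O)c1cccc(C(F)(F)F)c1)N[C@@H]1CCCc2cc(CN3CCC3)ccc21`, is not yet measured. It differs from compound 2 in one place: azetidin-1-yl in place of cyclopropylamino on a saturated chain carbon bound to an aromatic carbon.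

Among the measured compounds shown here, the single measured step concerns the same amine nitrogen, but it swaps one substituent on that nitrogen for another, whereas the present change closes the nitrogen into a ring. That step therefore bears only loosely on the question; no measured step of the same kind exists among these compounds. With so little to go on, the step of a 1.7-fold higher number from compound 2 to compound 3 (0.23 log units; within the scatter) is expected to be small, most likely within the scatter or a modest move in either direction. Compound 3 is therefore estimated at 80 nM in this assay, with a range from 25 nM to 250 nM.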

Compound 3, half-maximal inhibitory concentration: 4300 nM
The estimate for compound 3 lay 54-fold (1.73 log units) below the measured number; the whole stated range lies below it.
By their numbers in this assay, from the lowest: compound 2; then compound 1; then compound 3.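

In this assay, the change at this saturated chain carbon bound to an aromatic carbon proves far from neutral: going to azetidin-1-yl gives a 91-fold higher number from compound 2 to compound 3 (1.96 log units; beyond the scatter) even though the entering and leaving groups each have 4 heavy atoms, with cyclopropylamino carrying 1 hydrogen-bond donor and azetidin-1-yl 0 hydrogen-bond donors. Replacing neopentylamino with the same ring gives a 19-fold higher number from compound 1 to compound 3 (1.27 log units; beyond the scatter) as well, so among these three compounds, the two that keep a hydrogen on the amine nitrogen both have much lower numbers than the ring compound, and none of the three goes against this. Nothing shown here accounts for the size of these losses or says which feature of the change matters.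

The compounds shown leave open whether the loss goes with the missing hydrogen on the nitrogen or with the ring itself, and an open-chain dimethylamino group on the same carbon would help to separate the two. They also leave open whether a larger ring on that nitrogen, such as pyrrolidine or piperidine, would behave as azetidin-1-yl does.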